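The source may report more compounds than this note shows. Statements on the series, on what has been measured and on what is new or still open speak of the compounds shown alone.

Measured in an ADME assay on a cell-free system (plasma, Mus musculus) for protein binding:
Compound 1 `CNc1nccc(N2CC[C@H](NC(=O)Nc3ccc(CN(C)C)c(C(F)(F)F)c3)C2)n1`: 87.8%
Compound 2 `CNc1nccc(N2CC[C@H](NC(=O)Nc3cc(OC)cc(OC)c3)C2)n1`: 96.9%
Compound 3 `CNc1nccc(N2CC[C@H](NC(=O)Nc3ccc(C)c(Cl)c3)C2)n1`: 98.6%

Compound 1 has the largest unbound fraction of the three, and its gaps to compound 2 and compound 3 both lie beyond the scatter. Compound 4 `CNc1nccc(N2CC[C@H](NC(=O)Nc3ccc(CN4CCN(C)CC4)c(C(F)(F)F)c3)C2)n1` differs from it in one place, with 4-methylpiperazin-1-yl in place of dimethylamino on a saturated chain carbon bound to an aromatic carbon. Going by the values given here, no measured pair shows this swap, so any forecast is loose. Among the compounds with values here, compound 1, at 87.8%, is the only measured compound carrying dimethylamino, and compound 4 is expected to stay nearer to it than to the other two. A slight shift towards more binding is expected, with no step beyond the scatter: a 1.1-fold lower unbound fraction from compound 1 to compound 4 (0.04 log units; within the scatter). For compound 4 the estimated value is 89%, within an expected range of 76% to 96%.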

Compound 4, plasma protein binding: 85.8%
For compound 4 the middle estimate is 1.3-fold (0.11 log units) (unbound fraction) below the measured one; the measured number falls inside the stated range.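

In this assay, putting 4-methylpiperazin-1-yl in place of dimethylamino on the saturated chain carbon bound to an aromatic carbon gives a 1.2-fold higher unbound fraction from compound 1 to compound 4 (0.07 log units; within the scatter). Going by these compounds alone, this is the first one-place comparison here, and it shows that this position accepts a six-membered non-aromatic ring with no change in binding that can be told from ordinary repeat scatter. No available evidence accounts for this result. Going by these compounds, whether morpholin-4-yl or a carboxylic acid at this place would behave alike remains open, and so does whether this swap would give the same result on a different aromatic substitution pattern.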